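A sulfonyl swap on compound 2

The source may report more compounds than this note shows. Statements on the series, on what has been measured and on what is new or still open speak of the compounds shown alone.

In a functional assay on HepG2 cells (Homo sapiens) for antiproliferative activity, read by MTT assay, with a stated time of 24 h (on this read-out higher numbers stand for weaker inhibition and lower numbers for stronger inhibition), compound 2 (`O=S(=O)(c1ccccc1)n1c(-c2cn(-c3ccccc3)nc2-c2ccc(C(F)(F)F)cc2)nc2ccccc21`) gives 590 nM. Compound 1 (`Cc1ccc(-c2nn(-c3ccccc3)cc2-c2nc3ccccc3n2S(=O)(=O)c2cc(C)ccc2C)cc1`), which also carries 2,5-dimethylphenyl on a sulfonyl sulfur, gives 460 nM, and these two numbers lie within the scatter of each other. Compound 3 (`Cc1ccc(C)c(S(=O)(=O)n2c(-c3cn(-c4ccccc4)nc3-c3ccc(C(F)(F)F)cc3)nc3ccccc32)c1`) has 2,5-dimethylphenyl in place of phenyl on a sulfonyl sulfur of compound 2 (2,5-dimethylphenyl in place of phenyl on a sulfonyl sulfur). Going by the values given here, no measured pair shows this change alone, so the expectation rests on compound 1 at 460 nM: no step beyond the scatter in this assay. The expected step is small, a 1.2-fold lower number from compound 2 to compound 3 (0.07 log units; within the scatter). For compound 3 the estimated value is 500 nM, with an expected range of 200 nM to 1300 nM.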

Compound 3, half-maximal inhibitory concentration: 330 nM
Beside the measured number, compound 3's estimate is 1.5-fold (0.18 log units) above it; low and high end bracket the measured number.
By their numbers in this assay, from the lowest: compounds 3, 1 and 2 (each within the scatter of the next).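

In this assay, going by these compounds alone, the only direct pair for this position shows that 2,5-dimethylphenyl in place of phenyl on a sulfonyl sulfur stays within the scatter (a 1.8-fold lower number from compound 2 to compound 3 (0.25 log units; within the scatter)). With 2,5-dimethylphenyl held on that sulfur, trifluoromethyl in place of methyl on an aromatic carbon also stays within the scatter (a 1.4-fold lower number from compound 1 to compound 3 (0.14 log units; within the scatter)). No measurement shown here offers an explanation for either result. Still open, going by these compounds, is whether a different group on the sulfonyl sulfur, such as a short alkyl chain or an aminophenyl, would give a step beyond the scatter.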